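Ring Contraction on the Amine of Compound 1

The source may report more compounds than this note shows. Statements on the series, on what has been measured and on what is new or still open speak of the compounds shown alone.

Among the compounds with values here, compound 1 `CCn1c(-c2ccccc2)nc2c(NC3CCCCC3)ncnc21` is the only member of this set that gives a number rather than a limit in a functional assay on CHO cells for antagonist activity at adenosine receptor A2b (Homo sapiens), read by 33P incorporation, with a stated time of 20 min (on this read-out higher numbers stand for weaker inhibition and lower numbers for stronger inhibition), where compound 1 gives 9020 nM. Compound 2 `Cn1c(-c2ccccc2)nc2c(NC3CCCCC3)ncnc21` reaches only the limit of the assay, giving > 30000 nM. Compound 3 `Cc1ccccc1-c1nc2c(NC3CCCC3)ncnc2n1C` also sits at the limit of the assay, giving > 30000 nM. Within the data shown here, the single measured step, an at least 3.3-fold higher number from compound 1 to compound 2 (0.52 log units; beyond the scatter), ends at the limit of > 30000 nM in this assay, at which 2 of the 3 values shown sit, and concerns the saturated carbon on the aromatic nitrogen, not the amine. Compound 4 `CCn1c(-c2ccccc2)nc2c(NC3CCCC3)ncnc21` carries cyclopentyl in place of cyclohexyl on a nitrogen on an aromatic ring. Among the measured compounds shown here, no measured step touches this change, and compound 3, which holds cyclopentyl, differs from the others in two further places. A modest weakening, a 1.7-fold higher number from compound 1 to compound 4 (0.22 log units; within the scatter), is expected. For compound 4 the estimate is 15000 nM, with a range from 5000 nM to 40000 nM.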

Compound 4, inhibition constant: 5790 nM
Compound 4: the middle estimate sits 2.6-fold (0.41 log units) above what was measured; measured number inside the range.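

Within the data shown here, the first measured change on the amine, a 1.6-fold lower number from compound 1 to compound 4 (0.19 log units; within the scatter), shows that in this assay cyclopentyl and cyclohexyl on a nitrogen on an aromatic ring cannot be told apart at this position. The earlier step concerned only the saturated carbon on the aromatic nitrogen and left the amine untested. Like compound 1, compound 4 returns a number rather than a limit: the limit of > 30000 nM in this assay, at which 2 of the 4 values shown sit.

As far as these compounds go, whether a smaller ring such as cyclobutyl, an open chain such as isopropyl or an aromatic phenyl on this nitrogen would also return a number remains open.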